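The source may report more compounds than this note shows. Statements on the series, on what has been measured and on what is new or still open speak of the compounds shown alone.

Compound 1 `CC#CCn1c(N2CCC[C@@H](N)C2)cc(=O)n(Cc2cccc(C(=O)O)c2Br)c1=O` and compound 3 `CC#CCn1c(N2CCC[C@@H](N)C2)cc(=O)n(Cc2cc(C(=O)O)ccc2Br)c1=O` share one core and contain the same atoms joined differently: 2-bromo-3-carboxyphenyl in place of 2-bromo-5-carboxyphenyl on a saturated chain carbon bound to an aromatic nitrogen. In an assay on isolated protein for inhibition of Dipeptidyl peptidase 9 (Homo sapiens), read by fluorescence, with stated times of 15 min and 20 min (a lower number here means a stronger inhibitor, a higher number a weaker inhibitor), compound 1 gives "not determined" (no result reported). In this assay compound 3 gives > 100 nM, which is a limit of the assay and not a number. Compound 2 `CC#CCn1c(N2CCC[C@@H](N)C2)cc(=O)n(Cc2cc(C(=O)OC)ccc2Br)c1=O` gives > 100 nM in this assay, again a limit rather than a number. The change from compound 3 to compound 2 is methyl in place of hydrogen on an oxygen next to a carbonyl group, and the step that the two limits leave unreadable from compound 3 to compound 2 cannot be sized because both values sit at the limit of > 100 nM in this assay, at which 2 of the 3 values shown sit. Compound 4 `CC#CCn1c(N2CCC[C@@H](N)C2)cc(=O)n(Cc2cccc(C(=O)OC)c2Br)c1=O` carries the same kind of change from compound 1, (methyl in place of hydrogen on an oxygen next to a carbonyl group), at a place described in the same words. With two of three neighbours resting at the limit, compound 4 is expected to fall near 300 nM, likely between 100 nM and 2000 nM, and may itself be reported only as a limit.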

Compound 4, half-maximal inhibitory concentration: > 100 nM
Compound 4: a limit, no number (the forecaster's own chance of this, stated with the estimate: 70%); the middle value does not contradict the limit.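

No step can be read between compound 1 and compound 4; in this assay compound 4 gives > 100 nM, which is a limit and not a number. The compounds shown leave open how strongly each one inhibits the enzyme: the limit of > 100 nM in this assay, at which 3 of the 4 values shown sit.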